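The compounds below may be only part of what the source reports. "The series", "measured", "known", "first", "only" and "open" are said of these compounds alone.

Compound 3 `Cn1cncc1CN1CC(N(CC2CCN(C(=O)N3CCCCC3)CC2)S(=O)(=O)c2ccccn2)Cc2cc(C#N)ccc21` gives 0.6 10^-6 cm/s in an ADME assay on Caco-2 cells (Homo sapiens) for permeability, in the apical to basolateral direction (a higher number here means that the compound crosses the layer faster, a lower number that the compound crosses the layer more slowly), the highest of the three measured numbers, though compound 1 `Cn1cncc1CN1CC(N(CC2CCN(C(=O)CNC(=O)OC(C)(C)C)CC2)S(=O)(=O)c2ccccn2)Cc2cc(C#N)ccc21`, with 0.5 10^-6 cm/s, sits within the scatter of it, while compound 2 `Cn1cncc1CN1CC(N(CC2CCN(S(C)(=O)=O)CC2)S(=O)(=O)c2ccccn2)Cc2cc(C#N)ccc21`, with 0.1 10^-6 cm/s, lies clearly beneath both. Compound 4 `CC(=O)N1CCC(CN(C2Cc3cc(C#N)ccc3N(Cc3cncn3C)C2)S(=O)(=O)c2ccccn2)CC1` differs from compound 3 by methyl in place of piperidin-1-yl on a carbonyl carbon. Going by the values given here, two measured steps bear on this change at the same amine nitrogen in a ring: a 1.2-fold higher number from compound 1 to compound 3 (0.08 log units; within the scatter), and a 6.0-fold higher number from compound 2 to compound 3 (0.78 log units; beyond the scatter). The smaller replacement in compound 4 lies between those precedents, so a modest downward step is expected, a 2.0-fold lower number from compound 3 to compound 4 (0.30 log units; within the scatter). Compound 4 is therefore estimated at 0.3 10^-6 cm/s in this assay, with a range from 0.1 10^-6 cm/s to 0.8 10^-6 cm/s.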

Compound 4, apparent permeability: 0.5 10^-6 cm/s
For compound 4 the middle estimate is 1.7-fold (0.22 log units) below the measured one, within the range that was stated.
By their numbers in this assay, from the lowest: compound 2; then compounds 1, 4 and 3 (each within the scatter of the next).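

In this assay, methyl on this carbonyl carbon reads the same as piperidin-1-yl (a 1.2-fold lower number from compound 3 to compound 4 (0.08 log units; within the scatter)), and the acetyl group of compound 4 also matches the longer carbamate-bearing chain (no change at the digits printed from compound 1 to compound 4 (within the scatter)). Among the four compounds, only methylsulfonyl on the amine nitrogen in a ring stands apart (a 5.0-fold higher number from compound 2 to compound 4 (0.70 log units; beyond the scatter)), so the three carbonyl-linked groups shown read alike.

No measurement shown accounts for this gap. Going by these compounds, it remains open whether a carboxylic acid or an amine on the acetyl chain, or phenylsulfonyl on this nitrogen, would fit either level.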